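Series notes: methoxy replaced by trifluoromethyl on compound 1

The source may hold more compounds than are shown below. What is called first, only, known or untested is meant among the compounds shown, and "the series" means these compounds.

Three compounds carry numbers in a functional assay on HCT-116 cells (Homo sapiens) for antiproliferative activity; on this read-out lower numbers stand for stronger inhibition and higher numbers for weaker inhibition. Compound 1 `COc1ccc2c(c1)[nH]c1c2c2c(c3c4cccc5c4n(c13)CC(CO)C5)C(=O)NC2=O` gives 1830 nM, the highest of the three numbers. Compound 2 `O=C1NC(=O)c2c1c1c3ccccc3ccc1c1c2c2cccc3c2n1CC(CO)C3` gives 940 nM and compound 3 `O=C1NC(=O)c2c1c1c3ccccc3ccc1c1c2c2cccc3c2n1C(CO)CC3` gives 1120 nM; both gaps to compound 1 lie within the scatter, so no order among the three can be read from these values. Within the data shown here, compound 2 and compound 3 each differ from compound 1 in more than one place, so none of the measured pairs offers a single-point step.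

Compound 4 `O=C1NC(=O)c2c1c1c3ccc(C(F)(F)F)cc3[nH]c1c1c2c2cccc3c2n1CC(CO)C3` has not been measured. It differs from compound 1 in one place: trifluoromethyl in place of methoxy on an aromatic carbon. Among the measured compounds shown here, no measured single-point step gives a size to compare with, so the size of this change is open. The expected step from compound 1 to compound 4 in this assay is a 1.2-fold lower number from compound 1 to compound 4 (0.09 log units; within the scatter), no step beyond the scatter in either direction. For compound 4 the estimated value in this assay is 1500 nM, with a range from 500 nM to 4500 nM.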

Compound 4, half-maximal inhibitory concentration in the HCT-116 assay: 1250 nM
Estimate against measurement, compound 4: 1.2-fold (0.08 log units) above; measured number inside the range.
By their numbers in the HCT-116 assay, from the lowest: compounds 2, 3, 4 and 1 (each within the scatter of the next).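

In the HCT-116 assay the series now has a single-point step, a 1.5-fold lower number from compound 1 to compound 4 (0.17 log units; within the scatter), so trifluoromethyl in place of methoxy on an aromatic carbon, meta to a fused ring and para to a fused ring, brings no readable change in antiproliferative activity. In a physicochemical assay for solubility (on this read-out higher numbers stand for higher solubility and lower numbers for lower solubility), compound 1 gives 490 ug/mL and compound 4 gives 4810 ug/mL, so the same replacement does separate the two compounds, and the two read-outs respond differently to this one change: the measured solubility of compound 1, 490 ug/mL, and of compound 4, 4810 ug/mL, a 9.8-fold higher number (0.99 log units; beyond the scatter)

On these data alone, whether the two read-outs stay apart with an amine or a carboxylic acid on this aromatic carbon remains open. The compounds shown also do not tell whether trifluoromethyl on another aromatic carbon of the shared core would give the same picture.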